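The compounds below may be only part of what the source reports. "The series", "measured", "known", "first", "only" and "open" are said of these compounds alone.

Three compounds carry a result in an ADME assay on HEL cells (Homo sapiens) for cytotoxicity, with a stated time of 3 days (on this read-out higher numbers stand for lower toxicity in this test and lower numbers for higher toxicity in this test), and the account follows the change from compound 3 to compound 4. Compound 1 `CCC1(Cc2ccccc2)OS(=O)(=O)C=C1OCc1ccc(Cl)c(Cl)c1` gives 36700 nM in this assay. Compound 2 `O=S1(=O)C=C(OCc2ccccc2)C(Cc2ccccc2)(Cc2ccccc2)O1` gives 200000 nM in this assay. Compound 3 `CCC1(Cc2ccccc2)OS(=O)(=O)C=C1OCc1ccc(Cl)cc1` is reported only as a limit of this assay, > 200000 nM, so it has no exact number. Compound 3 therefore stands at the far end of the measured set, at the limit of > 200000 nM in this assay, at which 1 of the 3 values shown sits, and no value among the three is known to lie higher.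

Within the data shown here, the single step that bears on the neighbourhood of compound 3 is an at least 5.4-fold higher number from compound 1 to compound 3 (0.73 log units; beyond the scatter), which moved the number in the direction of lower toxicity. Compound 4 `CCC1(Cc2ccccc2)OS(=O)(=O)C=C1OCC1CCCCC1` differs from compound 3 by cyclohexyl in place of 4-chlorophenyl on a saturated chain carbon bound to an oxygen on an unsaturated carbon. Among the measured compounds shown here, no measured step shows this kind of change, so the expectation rests on the position of compound 3 and on the values of compound 1 and compound 2, both of which also sit at the less toxic end of the scale.

Compound 4 is expected to give about 150000 nM in this assay, with a range from 40000 nM to 300000 nM. The step from compound 3 is estimated as an at least 1.3-fold lower number from compound 3 to compound 4 (0.12 log units; that floor lies within the scatter), which is expected to be a small one, likely within the scatter, with a fair chance that the result again comes back only as a limit.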

Compound 4, half-maximal cytotoxic concentration: > 200000 nM
Compound 4 gave a limit, no number (the forecaster's own chance of this, stated with the estimate: 45%); at least 1.3-fold (0.12 log units) between middle value and limit.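

With cyclohexyl in place of 4-chlorophenyl, compound 4 is also reported only as a limit in this assay, > 200000 nM. The step between compound 3 and compound 4 cannot be read, so the two groups cannot be ranked, but a non-aromatic ring at this place also stays at the top of the scale: the limit of > 200000 nM in this assay, at which 2 of the 4 values shown sit. The other new step is an at least 5.4-fold higher number from compound 1 to compound 4 (0.73 log units; beyond the scatter), with cyclohexyl in place of 3,4-dichlorophenyl, so that group now stands apart from both 4-chlorophenyl and cyclohexyl at this place.

As far as these compounds go, how far compound 3 and compound 4 actually lie beyond the limit of the test remains unknown, and so does any difference between them. From the compounds shown here alone, it also remains open whether an amine or a carboxylic acid on the ring at this place, or a longer chain in place of cyclohexyl, would bring the number back down from the limit as the second chloro of the 3,4-dichlorophenyl group does.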